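One Swap on a Series Sitting at the Assay Limit

This account rests on a few compounds, and the source may have more. Where it says the series, first, only, none or still open, it means among the compounds named here.

Compound 1 `COc1cc(-n2ncnc2-c2ccc(F)cc2)cc(OC)c1OC`: > 10000 nM, a limit of the assay.
Compound 2 `COc1cc(-c2ncnn2-c2ccc(F)cc2)cc(OC)c1OC`: > 10000 nM, a limit of the assay.
Compound 3 `COc1cc(-n2ncnc2-c2ccc(Cl)cc2)cc(OC)c1OC`: > 10000 nM, a limit of the assay.

Of the compounds shown here, three have been tested in a functional assay on A549 cells (Homo sapiens) for antiproliferative activity, read by MTT assay, with a stated time of 72 h; on this read-out higher numbers stand for weaker inhibition and lower numbers for stronger inhibition. Compound 1 gives > 10000 nM, which is a limit rather than a number. Compound 2 gives > 10000 nM, also a limit. Compound 3 gives > 10000 nM, again a limit. Going by the values given here, because of the limit of > 10000 nM in this assay, at which 3 of the 3 values shown sit, the only step between measured compounds, a step that the two limits leave unreadable from compound 1 to compound 3, cannot be read. Compound 4 `COc1cc(-n2ncnc2-c2ccc(SC)cc2)cc(OC)c1OC` differs from compound 3 by methylsulfanyl in place of chloro on an aromatic carbon. Among the compounds with values here, no measured step bears on this change, and compound 3 stands only at a limit. For compound 4 the expected value is estimated at 15000 nM, with an estimated lower end of 3000 nM and an estimated upper end of 60000 nM, most likely reported again as a limit. The expected step that the limit leaves unreadable from compound 3 to compound 4 is estimated to stay within the scatter.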

Compound 4, half-maximal inhibitory concentration: 800 nM
For compound 4 the middle estimate is 19-fold (1.27 log units) above the measured one; the whole stated range lies above it.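

This position on the aromatic ring is not silent: the series now has its first readable value. In this assay, methylsulfanyl in place of chloro gives an at least 12-fold lower number from compound 3 to compound 4 (1.09 log units; beyond the scatter), and methylsulfanyl in place of fluoro gives an at least 12-fold lower number from compound 1 to compound 4 (1.09 log units; beyond the scatter). Both steps are minimums rather than exact sizes because the starting compounds sit at a limit: the limit of > 10000 nM in this assay, at which 3 of the 4 values shown sit.

As far as these compounds go, whether a methoxy group or an amine at this same place would also bring a readable value stays open. So does whether a longer chain on the sulfur, such as ethylsulfanyl, would lower the number further.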